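The source may report more compounds than this note shows. Statements on the series, on what has been measured and on what is new or still open speak of the compounds shown alone.

Measured in a functional assay on MDA-MB-231 cells (Homo sapiens) for cytotoxicity, read by MTT assay, with a stated time of 96 h; a higher number here means a weaker inhibitor, a lower number a stronger inhibitor:
- compound 1 `CC[C@H](N)C(=O)N[C@@H]1C(=O)N2[C@@H](CC[C@@H]1CCO)CC[C@H]2C(=O)NC(c1ccccc1)c1ccccc1`: 1800 nM
- compound 2 `CC[C@H](N)C(=O)N[C@@H]1C(=O)N2[C@@H](CC[C@@H]1CCNC(=O)c1ccccc1)CC[C@H]2C(=O)NC(c1ccccc1)c1ccccc1`: 930 nM
- compound 3 `CC[C@H](N)C(=O)N[C@@H]1C(=O)N2[C@@H](CC[C@@H]1CCNC(=O)NCc1ccccc1)CC[C@H]2C(=O)NC(c1ccccc1)c1ccccc1`: 10800 nM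

Of these three, compound 3 has the highest number, 10800 nM, which makes it the weakest inhibitor, with its steps to both others beyond the scatter. Compound 4 `CCNCC[C@H]1CC[C@H]2CC[C@@H](C(=O)NC(c3ccccc3)c3ccccc3)N2C(=O)[C@H]1NC(=O)[C@@H](N)CC` differs from compound 3 by ethyl in place of benzylcarbamoyl on an amine nitrogen.

Within the data shown here, no measured compound carries this ethylamino group, so no measured step matches the change exactly. The nearest evidence comes from changes at the same chain end. The two steps into compound 3 are a 6.0-fold higher number from compound 1 to compound 3 (0.78 log units; beyond the scatter) and a 12-fold higher number from compound 2 to compound 3 (1.06 log units; beyond the scatter). The remaining step, a 1.9-fold lower number from compound 1 to compound 2 (0.29 log units; within the scatter), shows the other two compounds close together.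

Among the measured compounds shown here, with only three compounds as a guide, removing the (benzylcarbamoyl)amino group is expected to bring the number partway back towards those two, a modest move to a lower number. The expected change is a 3.6-fold lower number from compound 3 to compound 4 (0.56 log units; beyond the scatter). For compound 4 the estimated value is 3000 nM, with an expected range from 900 nM to 10000 nM.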

Compound 4, half-maximal inhibitory concentration: 8000 nM
Compound 4: middle estimate off by 2.7-fold (0.43 log units), on the low side; the range from low to high includes it.
By their numbers in this assay, from the lowest: compounds 2 and 1 (each within the scatter of the next); then compounds 4 and 3 (each within the scatter of the next).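

In this assay, ethyl in place of benzylcarbamoyl on the amine nitrogen gives a 1.4-fold lower number from compound 3 to compound 4 (0.13 log units; within the scatter), so compound 3 and compound 4 cannot be told apart, although ethyl has far fewer atoms and no aromatic ring. The ethylamino end of compound 4 does not read like the benzamido or hydroxy ends, with an 8.6-fold higher number from compound 2 to compound 4 (0.93 log units; beyond the scatter) and a 4.4-fold higher number from compound 1 to compound 4 (0.65 log units; beyond the scatter). Among these four compounds, the number of atoms in the group therefore does not sort the values: ethyl pairs with the larger benzylcarbamoyl, while benzoyl pairs with the much smaller hydroxy end.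

No available evidence accounts for this grouping. The compounds shown leave open whether an acetyl group on the same nitrogen, or a free primary amine at the chain end, would read with the first pair or the second.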